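This account rests on a few compounds, and the source may have more. Where it says the series, first, only, none or still open, it means among the compounds named here.

Compound 3 `CCN(CC)C(=O)NCC/C(=C(\c1ccccc1)c1ccc(OC)cc1)c1ccccc1` stands at 40700 nM in a functional assay on MDA-MB-231 cells (Homo sapiens) for cytotoxicity, read by MTT assay, with a stated time of 72 h (a higher number here means a weaker inhibitor, a lower number a stronger inhibitor), and compound 2 `COc1ccc(/C(=C(/CCNC(=O)N2CCOCC2)c2ccccc2)c2ccccc2)cc1` at 42800 nM lies within the scatter of it, so the two cannot be told apart. Compound 1 `COc1ccc(/C(=C(/CCNC(=O)NC2CCCCC2)c2ccccc2)c2ccccc2)cc1` returns only a limit in this assay, > 50000 nM, as recorded in the limit of > 50000 nM in this assay, at which 1 of the 3 values shown sits. The steps of an at least 1.1-fold lower number from compound 1 to compound 2 (0.06 log units; that floor lies within the scatter) and an at least 1.2-fold lower number from compound 1 to compound 3 (0.08 log units; that floor lies within the scatter) therefore start from that limit and have a floor that itself falls within the scatter, and the step of a 1.1-fold lower number from compound 2 to compound 3 (0.02 log units; within the scatter) is within the scatter outright. None of the three groups tried on the carbonyl carbon has moved the number beyond the noise, and all three compounds remain weak in this assay.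

Compound 4 `COc1ccc(/C(=C(/CCNC(=O)C(=O)NCc2ccccc2)c2ccccc2)c2ccccc2)cc1` differs from compound 3 by benzylcarbamoyl in place of diethylamino on a carbonyl carbon. The change is larger than the earlier swaps, adding a second carbonyl and a benzyl amide, but nothing measured bears directly on such a group. Given that every change on this carbonyl carbon so far stayed within the scatter, as in a 1.1-fold lower number from compound 2 to compound 3 (0.02 log units; within the scatter), compound 4 is expected to show a step of a 1.0-fold lower number from compound 3 to compound 4 (0.01 log units; within the scatter), that is, no movement beyond the scatter. Compound 4 is accordingly estimated at 40000 nM, in a range from 15000 nM to 100000 nM, with a fair chance that only a limit is reported.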

Compound 4, half-maximal inhibitory concentration: 11500 nM
The estimate for compound 4 lay 3.5-fold (0.54 log units) above the measured number, outside the stated range (below it).
By their numbers in this assay, from the lowest: compound 4; then compounds 3 and 2 (each within the scatter of the next). At a limit, above all of these: compound 1.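

In this assay, benzylcarbamoyl on this carbonyl carbon is the only group shown to move the number beyond the scatter, with a 3.5-fold lower number from compound 3 to compound 4 (0.55 log units; beyond the scatter) and a 3.7-fold lower number from compound 2 to compound 4 (0.57 log units; beyond the scatter), whereas the step between diethylamino and morpholin-4-yl stayed within it. The comparison with cyclohexylamino points the same way, with an at least 4.3-fold lower number from compound 1 to compound 4 (0.63 log units; beyond the scatter), and this shows that the position does respond to the group it carries, although the two fully defined steps are only modest. Compound 1 is held only at a limit, and the step from it is a floor: the limit of > 50000 nM in this assay, at which 1 of the 4 values shown sits.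

The entering group brings in a second carbonyl and an aromatic ring together, and the compounds shown do not separate the two. On these data alone, it remains open whether a benzylamino group placed directly on the carbonyl carbon would keep the step, and whether a methyl amide or a phenethyl amide on the second carbonyl would keep, enlarge or lose it.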